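Replacing a Sulfonate Ester with a Diarylamine

The source may report more compounds than this note shows. Statements on the series, on what has been measured and on what is new or still open speak of the compounds shown alone.

Compound 1 `C=C[C@@](C)(/C=C/c1ccc(OS(=O)(=O)C(F)(F)F)cc1)CCC=C(C)C` gives > 36600 nM in an ADME assay on HEK293 cells (Homo sapiens) for cytotoxicity, with a stated time of 72 h; a higher number here means that more compound is needed for the effect, a lower number that less compound is needed. Compound 2 `C=C[C@@](C)(/C=C/c1ccc(OS(=O)(=O)c2ccc(C)cc2)cc1)CCC=C(C)C` gives > 36600 nM in the same assay. Compound 3 `C=C[C@@](C)(/C=C/c1ccc(O)cc1)CC/C=C(\C)C=O` gives > 36600 nM there too.

Each of these three values is a limit of the assay rather than a number. For compound 1 the value is a limit, so its position is known only as lying at or beyond it. For compound 2 the value is likewise a limit. For compound 3 the value is also a limit. Going by the values given here, all three results sit at the limit of > 36600 nM in this assay, at which 3 of the 3 values shown sit, so no compound can be placed relative to another on these numbers.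

Among the compounds with values here, only one pair differs in a single place: the change from trifluoromethyl to 4-methylphenyl on the sulfonyl sulfur, and there a step that the two limits leave unreadable from compound 1 to compound 2, so its size is not known.

Compound 4 `C=C[C@@](C)(/C=C/c1ccc(Nc2ccc(Cl)c(Cl)c2)cc1)CCC=C(C)C` is the compound not yet measured. It differs from compound 1 by (3,4-dichlorophenyl)amino in place of ((trifluoromethyl)sulfonyl)oxy on an aromatic carbon. Within the data shown here, none of the measured steps covers an exchange of this kind, and the one step that exists is unreadable, so there is no measured basis for expecting a step in either direction beyond the scatter.

Compound 4 is therefore expected to show an at least 1.2-fold lower number from compound 1 to compound 4 (0.08 log units; that floor lies within the scatter) relative to its parent. Compound 4 is estimated at 30000 nM, with a range from 6000 nM to 80000 nM, and with a fair chance that the assay again reports only a limit.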

Compound 4, half-maximal effective concentration: > 36600 nM
Compound 4: a limit, no number; the forecaster's own chance of this, stated with the estimate: 60%; middle value at least 1.2-fold (0.08 log units) from the limit.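

In this assay compound 4 gives > 36600 nM, which is a limit of the assay and not a number. Going by these compounds alone, no new step can therefore be read between compound 1 and compound 4: the limit of > 36600 nM in this assay, at which 4 of the 4 values shown sit. The compounds shown leave open how far each lies past this limit, and whether any exchange on the shared core alters the read-out.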